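Bicyclic Amine in Place of Piperidine on the Shared Core

This account rests on a few compounds, and the source may have more. Where it says the series, first, only, none or still open, it means among the compounds named here.

Of the compounds shown here, three built on a shared core have been tested in an ADME assay on Vero cells (Chlorocebus sabaeus) for cytotoxicity, with a stated time of 7 days; a lower number here means that less compound is tolerated, a higher number that more compound is tolerated. Compound 1 `COc1cccc(CN2C(=O)CN(C(=O)c3cc4cc(OC)ccc4o3)C[C@@H]2CCc2ccccc2)c1` gives 4500 nM in this assay. Compound 2 `COc1ccc2[nH]c(C(=O)N3CC(=O)N(Cc4ccccc4)[C@@H](CN4CCCCC4)C3)cc2c1` gives 76900 nM in this assay, and compound 3 `COc1ccc2[nH]c(C(=O)N3CC(=O)N(Cc4ccc[nH]4)[C@@H](Cc4ccccc4)C3)cc2c1` gives 15200 nM in this assay. Of these three numbers, compound 2 stands highest: compound 3 lies below it, compound 1 lies furthest below, and both gaps lie beyond the usual scatter of repeated measurements, so compound 2 is the best tolerated of the three.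

Compound 4 `COc1ccc2[nH]c(C(=O)N3CC(=O)N(Cc4ccccc4)[C@@H](CN4CC5CCCCC5C4)C3)cc2c1` has not yet been measured in this assay. It differs from compound 2 in one place: a group of 9 heavy atoms (8 carbon, 1 nitrogen; one five-membered non-aromatic ring with 1 hetero atom, one six-membered non-aromatic ring of carbon only) in place of a group of 6 heavy atoms (5 carbon, 1 nitrogen; one six-membered non-aromatic ring with 1 hetero atom), on a saturated chain carbon bound to a saturated ring carbon. A larger group with a second ring thus replaces the single piperidin-1-yl ring on the saturated chain carbon bound to a saturated ring carbon.

Among the compounds with values here, no pair of measured compounds shows a change of this kind, so the size of the step can only be expected, not read off. Because compound 2 gives 76900 nM, the highest of the three numbers, a modest move toward a lower number, roughly at the edge of the scatter, is expected for compound 4. Compound 4 is expected to give 40000 nM in this assay, within a range from 15000 nM to 100000 nM. This estimate means an expected step of a 1.9-fold lower number from compound 2 to compound 4 (0.28 log units; within the scatter).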

Compound 4, half-maximal cytotoxic concentration: 8200 nM
Estimate against measurement, compound 4: 4.9-fold (0.69 log units) above; the whole stated range lies above it.
By their numbers in this assay, from the lowest: compounds 1, 4 and 3 (each within the scatter of the next, the first and the last beyond it); then compound 2.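

In this assay, within the data shown here, the earlier compounds offered no step between neighbours, and this result supplies the first: putting the larger two-ring group in place of the piperidin-1-yl ring, on a saturated chain carbon bound to a saturated ring carbon, gives a 9.4-fold lower number from compound 2 to compound 4 (0.97 log units; beyond the scatter). It shows that the number responds to what this position carries, even though the leaving and entering groups have the same counts of hydrogen-bond donors and acceptors and neither has a net charge, so the computed differences are the added heavy atoms and the second ring. No measurement shown here explains the step, and its cause remains unknown.

From the compounds shown here alone, one step cannot separate the contribution of the added atoms from that of the second ring, so it remains open whether a single larger ring, such as azepan-1-yl, would give a similar number. Also open is where a morpholin-4-yl ring or an open-chain diethylamino group would fall at this position, and whether the same exchange would give a step of similar size on the other compounds shown.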